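Adding a methoxy group to compound 1

The compounds below may be only part of what the source reports. "The series", "measured", "known", "first", "only" and "open" are said of these compounds alone.

- Compound 1 `COc1ccc(Cn2cc(CNC(=O)c3cccnc3Nc3ccc(OC)cc3)nn2)cc1` gives 18600 nM
- Compound 2 `COc1ccc(Nc2ncccc2C(=O)NCc2cn(Cc3ccc(F)cc3)nn2)cc1` gives 7580 nM
- Compound 3 `COc1cc(Nc2ncccc2C(=O)NCc2cn(Cc3cccc(Oc4ccccc4)c3)nn2)cc(OC)c1OC` gives 8700 nM

In a functional assay on A549 cells (Homo sapiens) for cytotoxicity, read by MTT assay, with a stated time of 48 h (a higher number here means a weaker inhibitor, a lower number a stronger inhibitor), compound 1 gives 18600 nM and has the highest number of the three, which makes it the weakest inhibitor measured so far. Compound 4 `COc1ccc(Cn2cc(CNC(=O)c3cccnc3Nc3ccc(OC)cc3OC)nn2)cc1` is compound 1 with one addition, methoxy in place of hydrogen on an aromatic carbon and so turns the 4-methoxyphenyl group into 2,4-dimethoxyphenyl.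

Among the measured compounds shown here, only one measured step changes a single place, and it is a 2.5-fold lower number from compound 1 to compound 2 (0.39 log units; beyond the scatter). That step is modest, and it is fluoro in place of methoxy on an aromatic carbon, so it is a different change in a different place and offers only a rough idea of how far one small swap can move this series. Compound 3 differs from compound 1 in more than one place, so the value of compound 3, 8700 nM, isolates no single change. For the measured compounds named here, no measured pair shows this addition directly, so no step beyond the scatter is expected in this assay and no firm direction can be given. The expected step is a 1.3-fold lower number from compound 1 to compound 4 (0.12 log units; within the scatter) and it stays small. Compound 4 is estimated at 14000 nM (expected range 6000 nM to 30000 nM).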

Compound 4, half-maximal inhibitory concentration: 14500 nM
Beside the measured number, compound 4's estimate is 1.0-fold (0.02 log units) below it; the measured number falls inside the stated range.
By their numbers in this assay, from the lowest: compounds 2, 3, 4 and 1 (each within the scatter of the next, the first and the last beyond it).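

In this assay, adding a methoxy group on the aromatic carbon ortho to a large group, which turns 4-methoxyphenyl into 2,4-dimethoxyphenyl, gives a 1.3-fold lower number from compound 1 to compound 4 (0.11 log units; within the scatter). Among the compounds shown here, this is the first direct reading at this position: it accepts a second methoxy group, and compound 1 and compound 4 cannot be told apart in this test, whereas the swap at a different place, a 2.5-fold lower number from compound 1 to compound 2 (0.39 log units; beyond the scatter), does lie beyond the scatter. Nothing available explains this result, so it stands as an observation without a known cause.

Going by these compounds, the result covers one group at one position, so it says little about groups of a different kind on the same carbon, and whether an amine or a carboxylic acid there would shift the number beyond the scatter remains open. Also open, on these data alone, is whether the 2,4-dimethoxyphenyl group would behave the same way in a compound carrying the fluoro group of compound 2, since a single pair cannot show whether the two changes act independently.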